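The source may hold more compounds than are shown below. What is called first, only, known or untested is meant among the compounds shown, and "the series" means these compounds.

In a functional assay on MCF7 cells (Homo sapiens) for inhibition (on this read-out lower numbers stand for stronger inhibition and higher numbers for weaker inhibition), compound 1 (`CCCCCCCC[C@@]1(C)SC(=O)C=C1OC`) gives > 50 ug/mL, which is a limit of the assay and not a number. Going by the values given here, compound 2 (`CCCCCCCC[C@@]1(C)SC(=O)C=C1OC(=O)CC`) gives 22.6 ug/mL, the only true number so far.

The next structure is compound 3 (`CCCCCCCC[C@@]1(C)SC(=O)C=C1OC(=O)OCC`), and the change is ethoxy in place of ethyl on a carbonyl carbon. In short, it has ethoxy in place of ethyl on a carbonyl carbon, and it keeps the carbonyl group that compound 2 carries and compound 1 lacks.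

Among the compounds with values here, only one measured step bears on this: an at least 2.2-fold lower number from compound 1 to compound 2 (0.34 log units; beyond the scatter). That step changes the group on the oxygen as a whole, and its size is only a bound. Within the data shown here, no measured step alters the group on the carbonyl carbon itself, so it gives only weak guidance here. No step beyond the scatter is therefore expected in this assay, and neither direction is favoured with any confidence.

The expected change is a 1.1-fold higher number from compound 2 to compound 3 (0.04 log units; within the scatter). The limit seen so far remains a possible outcome: the limit of > 50 ug/mL in this assay, at which 1 of the 2 values shown sits. For compound 3 the estimated value is 25 ug/mL, with an expected range of 10 ug/mL to 60 ug/mL.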

Compound 3, half-maximal inhibitory concentration: 14.5 ug/mL
Compound 3: middle estimate off by 1.7-fold (0.24 log units), on the high side; the measured number falls inside the stated range.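

In this assay, going by these compounds alone, ethoxy in place of ethyl on a carbonyl carbon gives a 1.6-fold lower number from compound 2 to compound 3 (0.19 log units; within the scatter), so compound 2 and compound 3 read as equal within the scatter, and the added oxygen of the ethoxy group brings no separable step at this place. Ethoxycarbonyl in place of methyl on an oxygen on an unsaturated carbon gives an at least 3.4-fold lower number from compound 1 to compound 3 (0.53 log units; beyond the scatter), so a second group holding a carbonyl now repeats what propanoyl showed alone, though the size of this step is only a bound. Compound 1, with methyl on that oxygen, remains the one compound at a limit of the assay, which is not a number: the limit of > 50 ug/mL in this assay, at which 1 of the 3 values shown sits.

The compounds shown leave open whether any group on that carbonyl carbon would move the number beyond the scatter, for example an amine, a phenyl ring or an alkoxy chain longer than ethoxy. They also leave open whether a group without a carbonyl but larger than methyl on the same oxygen, such as a benzyl group, would also give a measurable number, which would separate the role of the carbonyl from that of size alone.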